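The compounds below may be only part of what the source reports. "The series", "measured", "known", "first", "only" and "open" are said of these compounds alone.

Measured compounds:
compound 1, `COCOc1cc(/C=C/C(=O)OCC(=O)Nc2ccc(OC)cc2)ccc1OCc1ccccc1`: in a functional assay on ECa-109 cells (Homo sapiens) for cytotoxicity, read by MTT assay, with a stated time of 72 h (a lower number here means a stronger inhibitor, a higher number a weaker inhibitor), compound 1 gives > 200000 nM
compound 2, `COCOc1cc(/C=C/C(=O)OCC(=O)Nc2ccc(Cl)cc2)ccc1OCc1ccccc1`: in this assay compound 2 gives > 200000 nM
compound 3, `COc1ccc(NC(=O)COC(=O)/C=C/c2cc(OC)c(OCc3ccc(Cl)c(Cl)c3)c(OC)c2)cc1`: in this assay compound 3 gives > 200000 nM

The value of compound 1 is a limit of this assay, not a number. The value of compound 2 is likewise a limit. The value of compound 3 is a limit as well. Compound 2 differs from compound 1 by chloro in place of methoxy on an aromatic carbon. The step this made, a step that the two limits leave unreadable from compound 1 to compound 2, cannot be read because both compounds sit at the limit of > 200000 nM in this assay, at which 3 of the 3 values shown sit.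

Compound 4, `COc1cc(/C=C/C(=O)OCC(=O)Nc2ccc(Cl)cc2)cc(OC)c1OCc1ccc(Cl)c(Cl)c1`, is not yet measured. It differs from compound 3 by chloro in place of methoxy on an aromatic carbon, the same change at the same kind of place. The difference between the cores of compound 1 and compound 3 is not broken down here. The step from compound 3 to compound 4 is expected to be a step that the limit leaves unreadable from compound 3 to compound 4, resting on compound 3 sitting at the limit of > 200000 nM in this assay, at which 3 of the 3 values shown sit, and on the unreadable earlier step. Compound 4 is therefore estimated at about 300000 nM, between 150000 nM and 1000000 nM, most likely again only a limit.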

Compound 4, half-maximal inhibitory concentration: > 200000 nM
Compound 4 was reported as a limit; the forecaster's own chance of this, stated with the estimate: 85%; the middle value does not contradict the limit.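

Compound 3 and compound 4 are both reported only as limits, so the step between them, methoxy to chloro, cannot be read: the limit of > 200000 nM in this assay, at which 4 of the 4 values shown sit.

The compounds shown leave open how strong any of them actually is, and whether this swap changes anything.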